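Fluoro added next to a measured indanyl-imidazole

This account rests on a few compounds, and the source may have more. Where it says the series, first, only, none or still open, it means among the compounds named here.

Measured compounds:
- compound 1 `COCc1cccc2c1CC[C@H]2c1ncc[nH]1`, 37 nM
- compound 2 `CCOCc1cccc2c1CCC2c1ncc[nH]1`, 62 nM

In a functional assay on CHO cells for agonist activity at Alpha-1A adrenergic receptor (Homo sapiens), read by fluorescence and calcium flux (on this read-out lower numbers stand for an effect already at smaller amounts and higher numbers for an effect only at larger amounts of compound), compound 1 gives 37 nM, the lowest of the two numbers recorded. Compound 2 gives 62 nM in this assay, and the gap between the two lies within the scatter of repeated measurements, so nothing can be said about their order.

Compound 3 `COCc1c(F)ccc2c1CC[C@H]2c1ncc[nH]1` is not yet measured. Its structure differs from compound 1 in one place: fluoro in place of hydrogen on an aromatic carbon. Going by the values given here, no measured pair in this set shows what such a fluoro-for-hydrogen exchange does in this assay, so there is no step to lean on.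

For compound 3, the expected step of a 1.1-fold higher number from compound 1 to compound 3 (0.03 log units; within the scatter) is small and in no clear direction, no larger than the scatter. Compound 3 is therefore estimated at 40 nM in this assay, with a range of 12 nM to 130 nM.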

Compound 3, half-maximal effective concentration: 62 nM
Estimate against measurement, compound 3: 1.6-fold (0.19 log units) below; the range from low to high includes it.
By their numbers in this assay, from the lowest: compounds 1, 2 and 3 (each within the scatter of the next).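

Fluoro on the aromatic carbon ortho to a methoxymethyl group gives a 1.7-fold higher number from compound 1 to compound 3 (0.22 log units; within the scatter) in this assay and is the first fluoro-for-hydrogen exchange in this set that can be read. This position therefore accepts a fluoro without a change that stands out from the scatter, and agonist activity is retained. Going by these compounds alone, the single pair gives no direction for the exchange, and nothing at hand accounts for the size of this step.

As far as these compounds go, whether a chloro, a methyl or a methoxy group on this same carbon would also stay within the scatter of compound 1 remains open. From the compounds shown here alone, it is equally open whether a fluoro elsewhere on the aromatic ring would behave as it does here, or whether the same exchange would give a similar step with a longer chain in place of the methoxymethyl group.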